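Chloro on the benzylsulfanyl arm: second pass on pyrazole core

The source may hold more compounds than are shown below. What is called first, only, known or untested is meant among the compounds shown, and "the series" means these compounds.

Compound 2 `Cc1cc(S(=O)(=O)/N=C(\N)n2nccc2-c2ccccc2)c(SCc2ccccc2)cc1Cl` gives 12000 nM in a functional assay on HCT-116 cells (Homo sapiens) for cytotoxicity, read by MTT assay, with a stated time of 72 h; on this read-out lower numbers stand for stronger inhibition and higher numbers for weaker inhibition. Compound 1 `Cc1cc(S(=O)(=O)/N=C(\N)n2nccc2-c2ccccc2)c(SCc2cccc(Cl)c2)cc1Cl` carries chloro in place of hydrogen on an aromatic carbon and gives 7000 nM in this assay, a step of a 1.7-fold lower number from compound 2 to compound 1 (0.23 log units; within the scatter). Compound 3 `Cc1cc(-c2ccccc2)n(/C(N)=N/S(=O)(=O)c2cc(C)c(Cl)cc2SCc2ccccc2)n1` differs from compound 2 in its core by methyl in place of hydrogen on an aromatic carbon. In this assay compound 3 gives 10000 nM, a step of a 1.2-fold lower number from compound 2 to compound 3 (0.08 log units; within the scatter). All three values lie within the usual scatter of one another, so no order among them is claimed.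

Compound 4 `Cc1cc(-c2ccccc2)n(/C(N)=N/S(=O)(=O)c2cc(C)c(Cl)cc2SCc2cccc(Cl)c2)n1` is not yet measured. Within the data shown here, it differs from compound 3 by the change (chloro in place of hydrogen on an aromatic carbon), which is the same change, on the same place, as the one from compound 2 to compound 1; the cores differ as given by methyl in place of hydrogen on an aromatic carbon. Compound 4 is expected to sit at 6000 nM in this assay, a step of a 1.7-fold lower number from compound 3 to compound 4 (0.22 log units; within the scatter), estimated to fall between 3000 nM and 12000 nM. This rests on compound 1 showing a 1.7-fold lower number from compound 2 to compound 1 (0.23 log units; within the scatter) for the same change on the other core, a step that itself lies within the scatter.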

Compound 4, half-maximal inhibitory concentration: 18000 nM
Compound 4: middle estimate off by 3.0-fold (0.48 log units), on the low side; the whole stated range lies below it.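

In this assay, chloro on the benzyl arm gives a 1.8-fold higher number from compound 3 to compound 4 (0.26 log units; within the scatter), which alone is within the scatter, but set beside the other core the change does not carry over: the same change on two cores in this assay, a 1.7-fold lower number (0.23 log units; within the scatter) from compound 2 to compound 1 and a 1.8-fold higher number (0.26 log units; within the scatter) from compound 3 to compound 4, 3.1-fold (0.49 log units) apart, beyond the scatter of two such steps

The methyl on the core reads the same way, with a 2.6-fold higher number from compound 1 to compound 4 (0.41 log units; beyond the scatter), so its step depends on which arm is present: the same change on two cores in this assay, a 1.2-fold lower number (0.08 log units; within the scatter) from compound 2 to compound 3 and a 2.6-fold higher number (0.41 log units; beyond the scatter) from compound 1 to compound 4, 3.1-fold (0.49 log units) apart, beyond the scatter of two such steps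

For these four compounds the two changes therefore do not add, and a chloro step read on one core gave no usable guide to the other, but this rests on a single set of four compounds, does not show why the steps differ, and sets no rule for any other group.

The compounds shown leave open whether the same lack of additivity appears with fluoro, methoxy or a carboxylic acid in place of chloro on the benzyl ring. Going by these compounds, it is also open whether ethyl or an amine in place of the methyl on the core would behave as the methyl does.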